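Lengthening the Side Chain of Compound 2

A few compounds are considered here, and "the series" means these few. Any claim that something is new, unique, unknown or untested is made for them only; others in the source may bear on it.

Three close relatives share one core. Going by the values given here, in a functional assay on HeLa cells (Homo sapiens) for antiproliferative activity, read by sulforhodamine B assay (a higher number here means a weaker inhibitor of growth, a lower number a stronger inhibitor of growth), compound 1 `CC[C@@H]1O[C@H](COCc2ccccc2)[C@@H](OCc2ccccc2)[C@H](OCc2ccccc2)[C@H]1O` gives 19800 nM as the only exact number of the three. Compound 2 `CC[C@H]1O[C@H](COCc2ccccc2)[C@@H](OCc2ccccc2)[C@H](OCc2ccccc2)[C@H]1O` gives > 50000 nM as a limit of the assay and not a number. Compound 3 `CCCC[C@@H]1O[C@H](COCc2ccccc2)[C@@H](OCc2ccccc2)[C@H](OCc2ccccc2)[C@H]1O` gives > 50000 nM as a limit too. Compound 2 thus stands at the limit of > 50000 nM in this assay, at which 2 of the 3 values shown sit, and offers no exact starting number.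

Compound 4 `CC(C)C[C@H]1O[C@H](COCc2ccccc2)[C@@H](OCc2ccccc2)[C@H](OCc2ccccc2)[C@H]1O` differs from compound 2 by one change: isopropyl in place of methyl on a saturated chain carbon bound to a saturated ring carbon and this is isopropyl in place of methyl on a saturated chain carbon bound to a saturated ring carbon.

Among the compounds with values here, two measured steps bear on this: an at least 2.5-fold higher number from compound 1 to compound 2 (0.40 log units; beyond the scatter) with the fact that compounds 1 and 2 differ only in the configuration as drawn as its only difference, and an at least 2.5-fold higher number from compound 1 to compound 3 (0.40 log units; beyond the scatter) on placing ethyl where hydrogen stood. From the compounds shown here alone, both steps end at a limit, so their full size is unknown. Neither shows a larger chain restoring growth inhibition, so no gain is expected here. Within the data shown here, the expected change is a number no higher from compound 2 to compound 4 (the limit leaves the size open) in this assay with no step toward stronger inhibition beyond the scatter. Compound 4 is estimated at 50000 nM in this assay with an expected range of 20000 nM to 120000 nM and a good chance of falling at a limit of the assay.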

Compound 4, concentration for 50% growth inhibition: 43900 nM
Beside the measured number, compound 4's estimate is 1.1-fold (0.06 log units) above it; the measured number falls inside the stated range.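

In this assay, isopropyl in place of methyl on a saturated chain carbon bound to a saturated ring carbon gives an at least 1.1-fold lower number from compound 2 to compound 4 (0.05 log units; that floor lies within the scatter), so the part of the change that can be read does not go beyond the scatter. Going by these compounds alone, what the earlier compounds could not show is that the configuration drawn in compound 2 can carry an exact number at all: with the ethyl chain of compound 2 swapped for the isobutyl chain of compound 4, the value comes back inside the range the assay can read. Compound 4 therefore stands apart from the two compounds held at the limit, which is a limit of the assay and not a number: the limit of > 50000 nM in this assay, at which 2 of the 4 values shown sit.

From the compounds shown here alone, how far past its limit compound 2 truly lies stays open, so this step cannot tell whether the larger chain strengthens growth inhibition slightly, strongly or not at all. The compounds shown also leave open what a hexyl chain, or a chain ending in an amine or a carboxylic acid, would do at this place in this assay.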